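The source may report more compounds than this note shows. Statements on the series, on what has been measured and on what is new or still open speak of the compounds shown alone.

Measured so far in an ADME assay on HeLa cells (Homo sapiens) for cytotoxicity, read by crystal violet staining, with a stated time of 72 h; on this read-out higher numbers stand for lower toxicity in this test and lower numbers for higher toxicity in this test:
Compound 1, `CCOC(=O)c1cc(CCCOc2ccc(-c3noc(C(F)(F)F)n3)cc2[N+](=O)[O-])on1`, gives > 100000 nM, which is a limit of the test rather than a number.
Compound 2, `CN(C)C(=O)c1cc(CCCOc2ccc(-c3noc(C(F)(F)F)n3)cc2[N+](=O)[O-])on1`, gives 22500 nM.

Compound 1 thus stands only at the limit of > 100000 nM in this assay, at which 1 of the 2 values shown sits, so its true value is not pinned down. Within the data shown here, the one measured step, an at least 4.4-fold lower number from compound 1 to compound 2 (0.64 log units; beyond the scatter), concerns dimethylamino in place of ethoxy on a carbonyl carbon and leaves the nitro group untouched. Compound 3, `CCOC(=O)c1cc(CCCOc2ccc(-c3noc(C(F)(F)F)n3)cc2-n2cccc2)on1`, differs from compound 1 in another way: 1H-pyrrol-1-yl in place of nitro on an aromatic carbon. Among the measured compounds shown here, no measured step covers this change, so the expectation for compound 3 rests only on compound 1 sitting at a limit and on the single step seen, which was at least modest. The step of an at least 1.4-fold lower number from compound 1 to compound 3 (0.15 log units; that floor lies within the scatter) is therefore expected to be small or none beyond the scatter, with wide uncertainty. Compound 3 is estimated at 70000 nM, with a range from 15000 nM to 200000 nM.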

Compound 3, half-maximal cytotoxic concentration: 57300 nM
The estimate for compound 3 lay 1.2-fold (0.09 log units) above the measured number; low and high end bracket the measured number.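

Among these compounds, until now only the carbonyl end of the molecule had been varied, and compound 3 adds a first reading at the aromatic carbon that carries nitro in compound 1, ortho to a large group. In this assay, putting 1H-pyrrol-1-yl in place of nitro gives an at least 1.7-fold lower number from compound 1 to compound 3 (0.24 log units; that floor lies within the scatter), so this swap shows no change that can be called real, although a larger one is not excluded. The true size of the step stays unknown because the value for compound 1 is a limit: the limit of > 100000 nM in this assay, at which 1 of the 3 values shown sits.

The compounds shown leave open how an amine or a carboxylic acid would read at this same aromatic carbon. They also leave open whether 1H-pyrrol-1-yl and the dimethylamino group on the carbonyl carbon would act independently if combined in one molecule.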